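From 2-phenylethenyl to 2,3,4-trimethoxyphenyl on a shared core

This account rests on a few compounds, and the source may have more. Where it says the series, first, only, none or still open, it means among the compounds named here.

All three measured compounds were tested in a functional assay on OVCAR-3 cells (Homo sapiens) for antiproliferative activity, with a stated time of 48 h; a higher number here means that more compound is tolerated, a lower number that less compound is tolerated:

Compound 1, `Cc1cc(O)c(C2=NN(c3ccc(S(N)(=O)=O)cc3)C(c3ccccc3O)C2)cc1Cl`: 11300 nM
Compound 2, `Cc1cc(O)c(C2=NN(c3ccc(S(N)(=O)=O)cc3)C(/C=C/c3ccccc3)C2)cc1Cl`: 70200 nM
Compound 3, `COc1ccc(C2CC(c3cc(Cl)c(C)cc3O)=NN2c2ccc(S(N)(=O)=O)cc2)cc1OC`: 77500 nM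

Among these three numbers compound 2 stands second highest. Its nearest neighbour is compound 3, and the two lie within the scatter of each other, so no order between them can be claimed. Compound 1 is the furthest away, shown by the step of a 6.2-fold higher number from compound 1 to compound 2 (0.79 log units; beyond the scatter).

The unmeasured compound 4, `COc1ccc(C2CC(c3cc(Cl)c(C)cc3O)=NN2c2ccc(S(N)(=O)=O)cc2)c(OC)c1OC`, differs from compound 2 in one place: 2,3,4-trimethoxyphenyl in place of 2-phenylethenyl on a saturated ring carbon.

The step that bears most directly on this change is a 1.1-fold higher number from compound 2 to compound 3 (0.04 log units; within the scatter), where a 3,4-dimethoxyphenyl replaced the same 2-phenylethenyl and the number did not move beyond the scatter. The steps of a 6.2-fold higher number from compound 1 to compound 2 (0.79 log units; beyond the scatter) and a 6.9-fold higher number from compound 1 to compound 3 (0.84 log units; beyond the scatter) show that both of these groups sit at a similar distance from the 2-hydroxyphenyl of compound 1. A 2,3,4-trimethoxyphenyl is close in kind to the 3,4-dimethoxyphenyl of compound 3, so for compound 4 the expected step is a 1.1-fold higher number from compound 2 to compound 4 (0.05 log units; within the scatter), which is no change beyond the scatter in this assay. The estimate for compound 4 is therefore 78000 nM, with a range from 30000 nM to 200000 nM.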

Compound 4, concentration lethal to 50% of the cells: 7690 nM
Compound 4: middle estimate off by 10-fold (1.01 log units), on the high side, outside the stated range (below it).
By their numbers in this assay, from the lowest: compounds 4 and 1 (each within the scatter of the next); then compounds 2 and 3 (each within the scatter of the next).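

In this assay the methoxy in place of hydrogen on an aromatic carbon gives a 10-fold lower number from compound 3 to compound 4 (1.00 log units; beyond the scatter) and so a single added group moves the number beyond the scatter, which the earlier replacement of 2-phenylethenyl by 3,4-dimethoxyphenyl did not do. The full change on this saturated ring carbon, 2,3,4-trimethoxyphenyl in place of 2-phenylethenyl, appears as a 9.1-fold lower number from compound 2 to compound 4 (0.96 log units; beyond the scatter) and this shows that two phenyl groups carrying methoxy groups, alike as they look on paper, need not give alike numbers here. With a 1.5-fold lower number from compound 1 to compound 4 (0.17 log units; within the scatter) the 2,3,4-trimethoxyphenyl and the 2-hydroxyphenyl, though different groups, give numbers that cannot be told apart on these data.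

Nothing at hand explains why one more methoxy has so large an effect on this number. As far as these compounds go, it also remains open whether the effect belongs to the methoxy itself or would appear with any group on that aromatic carbon, a question that an ethoxy or an amine in the same place would help to answer.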